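The source may hold more compounds than are shown below. What is called first, only, known or untested is meant among the compounds shown, and "the series" means these compounds.

Working notes on the series. Compound 3 `CC(C)(C)c1ccc(C(=O)N2CCC3(CC2)C(=O)N(CC(=O)N2CCCC(CO)C2)CN3c2ccccc2)cc1` gives 8200 nM in an assay on HEK293 cells for displacement of a labelled ligand from NPC1-like intracellular cholesterol transporter 1 (Homo sapiens) (on this read-out higher numbers stand for weaker inhibition and lower numbers for stronger inhibition), the highest of the three numbers measured; compound 1 `CC(C)(C)c1ccc(C(=O)N2CCC3(CC2)C(=O)N(CC(=O)N2CCC(CCO)CC2)CN3c2ccccc2)cc1` gives 2600 nM and compound 2 `CC(C)(C)OC(=O)NCCCNC(=O)CN1CN(c2ccccc2)C2(CCN(C(=O)c3ccc(C(C)(C)C)cc3)CC2)C1=O` gives 4500 nM. The next compound, compound 4 `CC(C)(C)c1ccc(C(=O)N2CCC3(CC2)C(=O)N(CC(=O)N2CCNCC2)CN3c2ccccc2)cc1`, differs from compound 3 by piperazin-1-yl in place of 3-(hydroxymethyl)piperidin-1-yl on a carbonyl carbon. All three measured steps change the same amide substituent on that carbonyl carbon: a 3.2-fold higher number from compound 1 to compound 3 (0.50 log units; beyond the scatter), a 1.8-fold higher number from compound 2 to compound 3 (0.26 log units; within the scatter), and a 1.7-fold higher number from compound 1 to compound 2 (0.24 log units; within the scatter). Going by the values given here, none of them involves piperazin-1-yl, so the spread seen so far, modest at most, is the only guide. For compound 4 in this assay a step of a 1.5-fold lower number from compound 3 to compound 4 (0.17 log units; within the scatter) toward a somewhat lower number is expected, with the estimate 5500 nM and a range from 1800 nM to 17000 nM.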

Compound 4, half-maximal inhibitory concentration: 22000 nM
Estimate against measurement, compound 4: 4.0-fold (0.60 log units) below; the whole stated range lies below it.
By their numbers in this assay, from the lowest: compounds 1, 2 and 3 (each within the scatter of the next, the first and the last beyond it); then compound 4.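

With piperazin-1-yl on this carbonyl carbon, a 2.7-fold higher number from compound 3 to compound 4 (0.43 log units; beyond the scatter) and a 4.9-fold higher number from compound 2 to compound 4 (0.69 log units; beyond the scatter) and an 8.5-fold higher number from compound 1 to compound 4 (0.93 log units; beyond the scatter) all lie beyond the scatter, so this is the highest number at this position and the last step is the largest seen here. The leaving and entering groups in compound 3 and compound 4 have the same hydrogen-bond donor and acceptor counts, so those counts do not track this rise. No measurement on hand accounts for the step. From the compounds shown here alone, whether the rise follows the second ring nitrogen or the missing hydroxymethyl remains open. Morpholin-4-yl or 4-methylpiperazin-1-yl at the same carbonyl carbon would bear on that question.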